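The source may hold more compounds than are shown below. What is called first, only, known or untested is meant among the compounds shown, and "the series" means these compounds.

Compound 1 `ClCc1cccc(Cn2cnc3ncnc(Cl)c32)c1` and compound 2 `ClCc1ccccc1Cn1cnc2ncnc(Cl)c21` share their atoms but join them differently; the difference between the two cores is not broken down here. In a functional assay on MDA-MB-231 cells (Homo sapiens) for cytotoxicity, read by sulforhodamine B assay, with a stated time of 48 h (on this read-out higher numbers stand for weaker inhibition of growth and lower numbers for stronger inhibition of growth), compound 1 gives 1730 nM, while compound 2 gives 2750 nM, a pair that sits within the usual scatter. Compound 3 `ClCc1cccc(Cn2cnc3nc(Cl)nc(Cl)c32)c1` carries the change chloro in place of hydrogen on an aromatic carbon relative to compound 1, and in this assay compound 3 gives 460 nM; the step is a 3.8-fold lower number from compound 1 to compound 3 (0.58 log units; beyond the scatter). Compound 4 `ClCc1ccccc1Cn1cnc2nc(Cl)nc(Cl)c21` stands to compound 2 as compound 3 stands to compound 1, by the change (chloro in place of hydrogen on an aromatic carbon), the same change at the same place. Among the compounds with values here, compound 4 is expected to improve on compound 2 by about a 3.8-fold lower number from compound 2 to compound 4 (0.58 log units; beyond the scatter), because the step of a 3.8-fold lower number from compound 1 to compound 3 (0.58 log units; beyond the scatter) is the only guide to this change. Compound 4 is estimated at 720 nM in this assay, with a likely range from 350 nM to 1500 nM.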

Compound 4, concentration for 50% growth inhibition: 300 nM
For compound 4 the middle estimate is 2.4-fold (0.38 log units) above the measured one; the measured number lies below the stated range.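

In this assay chloro in place of hydrogen on an aromatic carbon gives a 9.2-fold lower number from compound 2 to compound 4 (0.96 log units; beyond the scatter), so the lowering seen on the core of compound 1 recurs on the core of compound 2. The two steps do not differ beyond the scatter, so the change carries across these two cores: the same change on two cores in this assay, a 3.8-fold lower number (0.58 log units; beyond the scatter) from compound 1 to compound 3 and a 9.2-fold lower number (0.96 log units; beyond the scatter) from compound 2 to compound 4, 2.4-fold (0.39 log units) apart, within the scatter of two such steps This rests on two pairs in a single assay and does not show that the step would hold on any further core, nor does it show why the number falls.

Open, as far as these compounds go, is how an amine, a methoxy group or a longer chain would compare with chloro at the same place, between two ring nitrogen atoms.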